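Pyrrolidine in place of methylpiperazine on a dichloro core

The source may hold more compounds than are shown below. What is called first, only, known or untested is meant among the compounds shown, and "the series" means these compounds.

Of the compounds shown here, three have been tested in an ADME assay on BHK cells (Mesocricetus auratus) for cytotoxicity, read by MTT assay, with a stated time of 96 h (a higher number here means that more compound is tolerated, a lower number that less compound is tolerated), so far. Compound 1 `Oc1ccc(-c2nc3cc(C(F)(F)F)ccc3[nH]2)cc1` gives only a limit of the assay, > 100000 nM; that is the limit of > 100000 nM in this assay, at which 1 of the 3 values shown sits. Compound 2 `CN1CCN(CC(=O)Nc2ccc(-c3nc4cc(Cl)c(Cl)cc4[nH]3)cc2)CC1` gives 41000 nM in this assay, the larger of the two numbers shown, though it sits within the scatter of compound 3 `Cn1c(-c2ccc(NC(=O)CN3CCCC3)cc2)nc2cc(C(F)(F)F)ccc21`, which gives 27000 nM. Compound 4 `O=C(CN1CCCC1)Nc1ccc(-c2nc3cc(Cl)c(Cl)cc3[nH]2)cc1` has not yet been measured in this assay. It differs from compound 2 in one place: pyrrolidin-1-yl in place of 4-methylpiperazin-1-yl on a saturated chain carbon bound to a carbonyl carbon. For the measured compounds named here, no measured pair shows this same change, so its effect is unknown; the step is expected to be a 1.2-fold lower number from compound 2 to compound 4 (0.09 log units; within the scatter), not beyond the scatter. Compound 4 is estimated to give 33000 nM in this assay, expected to lie between 12000 nM and 90000 nM.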

Compound 4, half-maximal cytotoxic concentration: 64000 nM
For compound 4 the middle estimate is 1.9-fold (0.29 log units) below the measured one; the measured number falls inside the stated range.
By their numbers in this assay, from the lowest: compounds 3, 2 and 4 (each within the scatter of the next, the first and the last beyond it). At a limit, above all of these: compound 1.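

For the compounds shown here, the step of a 1.6-fold higher number from compound 2 to compound 4 (0.19 log units; within the scatter) in this assay gives the first reading at this place, on a saturated chain carbon bound to a carbonyl carbon. Exchanging 4-methylpiperazin-1-yl for pyrrolidin-1-yl, with its smaller ring and one nitrogen fewer, leaves the two compounds within the scatter of each other on the shared core. Nothing measured here bears on a cause for this step. Going by these compounds, whether a morpholine ring or an open-chain dimethylamine at this place would also stay within the scatter remains open. This single pair also cannot say whether the same exchange would behave alike on another core.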